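Swapping phenyl for pyridin-4-yl on compound 3

A few compounds are considered here, and "the series" means these few. Any claim that something is new, unique, unknown or untested is made for them only; others in the source may bear on it.

Measured so far in a functional assay on HCT-15 cells (Homo sapiens) for cytotoxicity, read by ELISA, with a stated time of 2 days; a higher number here means a weaker inhibitor, a lower number a stronger inhibitor:
- compound 1 `Oc1cccc(-c2cc(-c3ccccc3)cc(-c3cccs3)n2)c1`: 10900 nM
- compound 2 `Oc1cccc(-c2cc(-c3ccccc3)cc(-c3ccncc3)n2)c1`: 27400 nM
- compound 3 `Oc1cccc(-c2cc(-c3ccccc3)nc(-c3ccccc3)c2)c1`: 18000 nM

Compound 3, at 18000 nM, cannot be ranked against the other two, since its value lies within the usual scatter of both compound 1 and compound 2. Only compound 1 and compound 2 stand apart from each other beyond that scatter.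

The next molecule, compound 4 `Oc1cccc(-c2cc(-c3ccccc3)nc(-c3ccncc3)c2)c1`, has not been measured yet. It is compound 3 with pyridin-4-yl in place of phenyl on an aromatic carbon.

Within the data shown here, only one measured step brings in the same group: a 2.5-fold higher number from compound 1 to compound 2 (0.40 log units; beyond the scatter). There, pyridin-4-yl replaces thiophen-2-yl, and the higher number means a weaker inhibitor. This is a loose guide, as the group leaving is not phenyl and the groups around the core are arranged differently. Among the measured compounds shown here, no measured pair shows phenyl leaving. A change in the same direction but of smaller size is therefore expected in this assay. The estimated change is a 1.4-fold higher number from compound 3 to compound 4 (0.16 log units; within the scatter), so only a small rise is expected. The estimate for compound 4 is 26000 nM, with an expected range from 13000 nM to 50000 nM.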

Compound 4, half-maximal inhibitory concentration: 18700 nM
Compound 4: middle estimate off by 1.4-fold (0.14 log units), on the high side; the range from low to high includes it.
By their numbers in this assay, from the lowest: compounds 1, 3, 4 and 2 (each within the scatter of the next, the first and the last beyond it).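

In this assay, putting pyridin-4-yl in place of phenyl on the aromatic carbon next to the ring nitrogen gives a 1.0-fold higher number from compound 3 to compound 4 (0.02 log units; within the scatter), so the two groups cannot be told apart at this position, even though the entering ring brings a nitrogen and one hydrogen-bond acceptor that phenyl lacks. Among these compounds, the only earlier step that brought in pyridin-4-yl was a 2.5-fold higher number from compound 1 to compound 2 (0.40 log units; beyond the scatter), where thiophen-2-yl left, and this new pair shows that the arrival of pyridin-4-yl does not by itself give a step beyond the scatter. Nothing measured here speaks to the reason for this result.

On these data alone, whether a group of a different kind at this position, such as an amine or a carboxylic acid, would give a step beyond the scatter remains open. All four compounds also carry the 3-hydroxyphenyl group, so what a methoxy group in place of its hydroxyl would do to the number in this assay is open as well.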